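Swapping the Aryl Halogen on the Core of Compound 3

The source may report more compounds than this note shows. Statements on the series, on what has been measured and on what is new or still open speak of the compounds shown alone.

Measured so far:
Compound 1, `O=S(=O)(c1ccc(F)cc1)c1cnc2c(F)cccc2c1-c1cccc(Cl)c1`: 1.21 mL/min in an ADME assay on microsomes from liver (Homo sapiens) for metabolic stability, tested at 2.5 uM; a higher number here means faster removal of the compound, a lower number slower removal
Compound 2, `Cc1ccc(S(=O)(=O)c2cnc3c(F)cccc3c2-c2cccc(Cl)c2)cc1F`: 3.18 mL/min in this assay
Compound 3, `N#Cc1cccc(S(=O)(=O)c2cnc3c(F)cccc3c2-c2cccc(Cl)c2)c1`: 1.11 mL/min in this assay

Among the compounds with values here, compound 3 has the lowest number of the three, but compound 1 sits within the scatter of it, so the two cannot be ordered; only the step of a 2.9-fold lower number from compound 2 to compound 3 (0.46 log units; beyond the scatter) is beyond the scatter. Compound 4, `N#Cc1cccc(S(=O)(=O)c2cnc3c(F)cccc3c2-c2ccc(F)cc2)c1`, differs from compound 3 by 4-fluorophenyl in place of 3-chlorophenyl on an aromatic carbon. Within the data shown here, none of the measured steps touches this position: a 2.6-fold higher number from compound 1 to compound 2 (0.42 log units; beyond the scatter) and a 1.1-fold lower number from compound 1 to compound 3 (0.04 log units; within the scatter) both change the group on the sulfonyl sulfur, so no measured step bears on the new change. The expected step is therefore a 1.1-fold lower number from compound 3 to compound 4 (0.05 log units; within the scatter), within the scatter. Compound 4 is estimated at 1 mL/min, with a range from 0.5 mL/min to 2.2 mL/min.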

Compound 4, intrinsic clearance in a liver preparation (reported as CLH), per the amount of preparation that the assay uses: 0.19 mL/min
Compound 4: the middle estimate sits 5.3-fold (0.72 log units) above what was measured, outside the stated range (below it).
By their numbers in this assay, from the lowest: compound 4; then compounds 3 and 1 (each within the scatter of the next); then compound 2.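

The swap of 3-chlorophenyl for 4-fluorophenyl gives a 5.8-fold lower number from compound 3 to compound 4 (0.77 log units; beyond the scatter) in this assay and is the first change shown on the aromatic carbon opposite the ring nitrogen, since the earlier steps all changed the group on the sulfonyl sulfur. Removal of the compound therefore depends on this position as well, not only on the sulfonyl group. Nothing measured here explains the drop.

Because the halogen and its place on the phenyl ring changed together, their contributions cannot be separated. As far as these compounds go, how an amine or a methoxy group on that ring would behave also remains open.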